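The source may report more compounds than this note shows. Statements on the series, on what has been measured and on what is new or still open speak of the compounds shown alone.

Compound 2 `COc1cc(-c2nn(-c3cccc(NC(=O)c4cccc(C(F)(F)F)c4)c3)cc2-c2ccncc2)ccc1Cl` carries an amide bearing a trifluoromethyl group, and in a functional assay on SNB-75 cells (Homo sapiens) for inhibition, read by sulforhodamine B assay, with a stated time of 48 h (a higher number here means a weaker inhibitor of growth, a lower number a stronger inhibitor of growth), compound 2 gives 1130 nM. Compound 1 `COc1cc(-c2nn(-c3cccc(NC(=O)Nc4cc(C(F)(F)F)cc(C(F)(F)F)c4)c3)cc2-c2ccncc2)ccc1Cl`, the urea analogue, gives 858 nM in this assay, and compound 3 `O=C(Nc1cccc(-n2cc(-c3ccncc3)c(-c3ccc(Cl)c(O)c3)n2)c1)Nc1cc(C(F)(F)F)cc(C(F)(F)F)c1` gives 877 nM; both sit within the scatter of compound 2, so the three are not distinguished. Among the compounds with values here, the only single-point step measured, a 1.0-fold higher number from compound 1 to compound 3 (0.01 log units; within the scatter), concerns hydrogen in place of methyl on an oxygen on an aromatic ring and does not touch the amide end. Compound 4 `COc1cc(-c2nn(-c3cccc(NC(=O)c4ccccc4)c3)cc2-c2ccncc2)ccc1Cl` differs from compound 2 by hydrogen in place of trifluoromethyl on an aromatic carbon. Within the data shown here, no measured step covers a change on this phenyl; the urea of compound 1 with two trifluoromethyl groups and the amide of compound 2 with one give numbers within the scatter of each other, which is the only hint available there. With nothing pointing either way, the estimated step is a 1.2-fold higher number from compound 2 to compound 4 (0.09 log units; within the scatter), that is, no movement expected beyond the scatter. The estimate for compound 4 in this assay is 1400 nM, with a range of 600 nM to 3500 nM.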

Compound 4, concentration for 50% growth inhibition: 575 nM
Estimate against measurement, compound 4: 2.4-fold (0.39 log units) above; measured number outside the range, below it.
By their numbers in this assay, from the lowest: compounds 4, 1, 3 and 2 (each within the scatter of the next).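

In this assay, within the data shown here, the step at this phenyl of the amide end, a 2.0-fold lower number from compound 2 to compound 4 (0.29 log units; within the scatter), is the first measured change made directly on that ring, and it stays inside the scatter. The trifluoromethyl group in this place, meta to a large group, is therefore not required for growth inhibition in this range, since the plain benzoyl amide of compound 4 remains indistinguishable from compound 2. Nothing available explains the size of this step.

As far as these compounds go, whether an amine or a carboxylic acid at this same position would move the number beyond the scatter remains open. Also open, from the compounds shown here alone, is whether removing both trifluoromethyl groups from the urea of compound 1 would likewise leave the number within the scatter.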